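Series notes: from compound 2 to compound 3

The source may report more compounds than this note shows. Statements on the series, on what has been measured and on what is new or still open speak of the compounds shown alone.

Measured so far:
compound 1 `C=CCOC(=O)Nc1ccc2nc(NC(=O)C3CCCCC3)sc2c1`: 0.58 ug/mL
compound 2 `NCCC(=O)Nc1nc2ccc(NC(=O)c3c(Cl)cccc3Cl)cc2s1`: 5.3 ug/mL

Among the compounds with values here, in a functional assay on WI-38 VA13 cells (Homo sapiens) for cytotoxicity (on this read-out lower numbers stand for an effect already at smaller amounts and higher numbers for an effect only at larger amounts of compound), compound 2 gives 5.3 ug/mL, the highest of the two numbers measured so far, while compound 1 sits at 0.58 ug/mL, a gap beyond the usual scatter. Compound 3 `O=C(Nc1nc2ccc(NC(=O)c3c(Cl)cccc3Cl)cc2s1)Oc1ccccc1` differs from compound 2 in one place: phenoxy in place of 2-aminoethyl on a carbonyl carbon. Within the data shown here, no step between measured compounds covers this exchange, so the expectation rests only on the two values in hand. A moderate shift toward a lower number is expected, a 2.7-fold lower number from compound 2 to compound 3 (0.42 log units; beyond the scatter), near the edge of the scatter. Compound 3 is estimated at 2 ug/mL, with a range from 0.6 ug/mL to 7 ug/mL.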

Compound 3, half-maximal effective concentration: 1.1 ug/mL
Estimate against measurement, compound 3: 1.8-fold (0.26 log units) above; low and high end bracket the measured number.
By their numbers in this assay, from the lowest: compounds 1 and 3 (each within the scatter of the next); then compound 2.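

In this assay, within the data shown here, phenoxy in place of 2-aminoethyl on a carbonyl carbon gives a 4.8-fold lower number from compound 2 to compound 3 (0.68 log units; beyond the scatter) and this is the first reading of a change at this position. The place therefore responds to the group it carries, and the carbonyl tolerates a six-membered aromatic ring as well as a ringless chain without loss of the effect. Nothing on hand accounts for the step. Still open, as far as these compounds go, is whether the ring or the linking oxygen carries the step, which a benzyl or phenyl group on the same carbonyl would separate. An ethoxy group or a longer aminoalkyl chain would show how far the response extends.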